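The source may report more compounds than this note shows. Statements on the series, on what has been measured and on what is new or still open speak of the compounds shown alone.

In an ADME assay on CHO-K1 cells (Cricetulus griseus) for cytotoxicity, read by MTT assay, with a stated time of 24 h (on this read-out lower numbers stand for higher toxicity in this test and higher numbers for lower toxicity in this test), compound 1 (`Oc1ccccc1NC(=S)Nc1ccc2[nH]ccc2c1`) gives 509000 nM and compound 2 (`Oc1ccc(NC(=S)Nc2ccc3[nH]ccc3c2)cc1`) gives 848000 nM while compound 3 (`COc1ccc(NC(=S)Nc2ccc3[nH]ccc3c2)cc1`) gives 476000 nM on the same shared core. Compound 3 thus sits with the other two, all three numbers lying within the usual scatter of one another.

Next comes compound 4 (`CCOC(=O)c1ccc(NC(=S)Nc2ccc3[nH]ccc3c2)cc1`), which carries ethoxycarbonyl in place of methoxy on an aromatic carbon, para to a large group (ethoxycarbonyl in place of methoxy on an aromatic carbon). Among the compounds with values here, no measured step brings in ethoxycarbonyl, so the evidence is indirect. The nearest is methyl in place of hydrogen on an oxygen on an aromatic ring (a 1.8-fold lower number from compound 2 to compound 3 (0.25 log units; within the scatter)), and on that step, which stays within the scatter, no change beyond the scatter is expected in this assay in either direction. The estimated step is small (a 1.1-fold lower number from compound 3 to compound 4 (0.02 log units; within the scatter)). Compound 4 is expected near 450000 nM with an estimated range from 200000 nM to 900000 nM on this read-out.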

Compound 4, concentration lethal to 50% of the cells: 123000 nM
Estimate against measurement, compound 4: 3.7-fold (0.56 log units) above; measured number below the stated range.
By their numbers in this assay, from the lowest: compound 4; then compounds 3, 1 and 2 (each within the scatter of the next).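

Within the data shown here, on the aromatic carbon para to a large group, ethoxycarbonyl is the first change in this assay to move the number beyond the scatter, with a 3.9-fold lower number from compound 3 to compound 4 (0.59 log units; beyond the scatter) and with a 6.9-fold lower number from compound 2 to compound 4 (0.84 log units; beyond the scatter) at the same place. Hydroxy and methoxy at this carbon stayed within the scatter of each other, so the earlier compounds gave no sign that this position could shift the read-out; here the shift runs towards higher toxicity in this test. Nothing measured in the compounds shown accounts for the shift.

Still open, on these data alone, is whether the shift belongs to the carbonyl or to the ethyl part of the ester, which a carboxylic acid or a methyl ester at this carbon would separate. Also open, as far as these compounds go, is how an amine at the same carbon would read in this test.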